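Methylating the Triazole on a Stable Core

The source may hold more compounds than are shown below. What is called first, only, known or untested is meant among the compounds shown, and "the series" means these compounds.

Compound 1 `CCC(CC)(c1nnc[nH]1)c1ccc(-c2ccc3cc(F)cc(F)c3c2)[nH]c1=O` and compound 2 `CCn1ncc2c(F)cc(-c3ccc(C(CC)(CC)c4nnc[nH]4)c(=O)[nH]3)cc21` share a core that carries a tertiary chain carbon bearing a triazole. In an ADME assay on microsomes from liver (Mus musculus) for metabolic stability (a higher number here means that the compound lasts longer, a lower number that the compound disappears faster), compound 1 gives 1.09 h. For compound 2 the reading in this assay is a limit of the assay rather than a number, > 3 h, which is the limit of > 3 h in this assay, at which 1 of the 2 values shown sits; compound 2 therefore stands at the upper edge of the numbers shown. Compound 3 `CCn1ncc2c(F)cc(-c3ccc(C(CC)(CC)c4ncn(C)n4)c(=O)[nH]3)cc21` has not yet been measured. It differs from compound 2 in one place: 1-methyl-1H-1,2,4-triazol-3-yl in place of 4H-1,2,4-triazol-3-yl on a saturated chain carbon bound to an aromatic carbon and two saturated chain carbons. Because compound 2 sits at the limit of > 3 h in this assay, at which 1 of the 2 values shown sits, the size of the step can only be gauged loosely; the expectation is a modest decrease or no change beyond the scatter, and the step that this expectation means is an at least 1.2-fold lower number from compound 2 to compound 3 (0.07 log units; that floor lies within the scatter). Compound 3 is accordingly estimated to give 2.5 h in this assay, within a range from 1.2 h to 3 h.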

Compound 3, half-life: > 3 h
Compound 3: only a limit was reported; the forecaster's own chance of this, stated with the estimate: 45%; middle value at least 1.2-fold (0.07 log units) from the limit.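

Compound 2 and compound 3 both stand at a limit of this assay rather than at a number, so no step between them can be read: the limit of > 3 h in this assay, at which 2 of the 3 values shown sit.

The compounds shown leave open whether 1-methyl-1H-1,2,4-triazol-3-yl in place of 4H-1,2,4-triazol-3-yl changes the half-life at all.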